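The compounds below may be only part of what the source reports. "The series", "measured", "known", "first", "only" and "open" are said of these compounds alone.

Measured so far in a functional assay on V79 cells (Cricetulus griseus) for cytotoxicity, read by colony formation; on this read-out higher numbers stand for weaker inhibition and lower numbers for stronger inhibition:
- compound 1 `Cc1c(F)c(N2CCC(N)C2)cc2c1c(=O)c(C(=O)O)cn2C1CC1`: 14 ug/mL
- compound 2 `Nc1c(F)c(N2CCC(N)C2)c(F)c2c1c(=O)c(C(=O)O)cn2C1CC1`: 15 ug/mL
- compound 3 `Nc1c(F)c(N2CCC(N)C2)c(Cl)c2c1c(=O)c(C(=O)O)cn2C1CC1`: 59 ug/mL

In this assay, compound 2 gives 15 ug/mL and sits level with compound 1 at 14 ug/mL, since their gap lies within the scatter. Only compound 3 stands apart, with a higher number and so weaker inhibition: a 3.9-fold higher number from compound 2 to compound 3 (0.59 log units; beyond the scatter).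

The next compound to be tested is compound 4 `Cc1c(F)c(N2CCC(N)C2)c(F)c2c1c(=O)c(C(=O)O)cn2C1CC1`. It departs from compound 2 in one place: methyl in place of amino on an aromatic carbon. This is methyl in place of amino on an aromatic carbon, ortho to a fluoro group and para to a fluoro group.

Among the compounds with values here, no measured step covers this swap. Within the data shown here, the one measured step, a 3.9-fold higher number from compound 2 to compound 3 (0.59 log units; beyond the scatter), is a chloro in place of fluoro, so it shows only that a single swap on this core can move the number modestly. Compound 1 is the closer guide. It carries methyl on the same carbon and gives 14 ug/mL, although it has no fluoro group para to that methyl. Going by these compounds, on this evidence, no step beyond the scatter is expected in this assay, and the direction stays open. The estimated step is a 1.3-fold lower number from compound 2 to compound 4 (0.10 log units; within the scatter). For compound 4 the expected value is 12 ug/mL, with an estimated range from 4 ug/mL to 36 ug/mL.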

Compound 4, half-maximal inhibitory concentration: 11 ug/mL
Compound 4: middle estimate off by 1.1-fold (0.04 log units), on the high side; low and high end bracket the measured number.
By their numbers in this assay, from the lowest: compounds 4, 1 and 2 (each within the scatter of the next); then compound 3.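

In this assay, methyl in place of amino on this aromatic carbon gives a 1.4-fold lower number from compound 2 to compound 4 (0.13 log units; within the scatter), so at this position, ortho to a fluoro group and para to a fluoro group, the hydrogen-bond donor and acceptor counted on amino can go without a step beyond the scatter. Fluoro in place of hydrogen on an aromatic carbon gives a 1.3-fold lower number from compound 1 to compound 4 (0.10 log units; within the scatter), so with methyl present, this second single change also stays within the scatter, while chloro in place of fluoro at that same carbon, with amino present, gives a 3.9-fold higher number from compound 2 to compound 3 (0.59 log units; beyond the scatter). No measurement shown here offers a reason for any of these steps.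

The compounds shown leave open whether a larger or different group on the carbon that holds amino or methyl, such as an ethyl, methoxy or hydroxyl group, would also stay within the scatter. They also leave open whether chloro on the other carbon would give a similar step with methyl in place of amino, as the chloro step shown comes from a compound carrying amino.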